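Moving the Nitro Group and Tolerance in Mouse Cells

This account rests on a few compounds, and the source may have more. Where it says the series, first, only, none or still open, it means among the compounds named here.

Compound 1 `COC(=O)c1c(NCCNc2ccnc3cc(Cl)ccc23)noc1-c1ccc([N+](=O)[O-])cc1` and compound 3 `COC(=O)c1c(NCCNc2ccnc3cc(Cl)ccc23)noc1-c1ccccc1[N+](=O)[O-]` share one core, while compound 2 `COC(=O)c1c(NCCCCNc2ccnc3cc(Cl)ccc23)noc1-c1ccc([N+](=O)[O-])cc1` and compound 4 `COC(=O)c1c(NCCCCNc2ccnc3cc(Cl)ccc23)noc1-c1ccccc1[N+](=O)[O-]` share another; the difference between the two cores is not broken down here. In an ADME assay on J774.A1 cells (Mus musculus) for cytotoxicity, read by MTT assay, with a stated time of 48 h (a higher number here means that more compound is tolerated, a lower number that less compound is tolerated), compound 1 gives 3790 nM, compound 3 gives 73600 nM, and compound 2 gives 136000 nM. Compound 2 and compound 3 lie within the scatter of each other. The change from compound 1 to compound 3 is 2-nitrophenyl in place of 4-nitrophenyl on an aromatic carbon, and it made a 19-fold higher number from compound 1 to compound 3 (1.29 log units; beyond the scatter). The same kind of change, (2-nitrophenyl in place of 4-nitrophenyl on an aromatic carbon), leads from compound 2 to compound 4. For the measured compounds named here, a smaller rise is expected in this assay, namely a 2.6-fold higher number from compound 2 to compound 4 (0.41 log units; beyond the scatter), because a 19-fold higher number from compound 1 to compound 3 (1.29 log units; beyond the scatter) is the only step of this kind seen here and compound 2 already sits high. Compound 4 is therefore expected to give 350000 nM, estimated between 100000 nM and 1500000 nM.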

Compound 4, half-maximal cytotoxic concentration: 77700 nM
Compound 4: the middle estimate sits 4.5-fold (0.65 log units) above what was measured; measured number outside the range, below it.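

Putting 2-nitrophenyl in place of 4-nitrophenyl did not carry over from one core to the other in this assay: on the second core the same change gives a 1.8-fold lower number from compound 2 to compound 4 (0.24 log units; within the scatter). Set beside the earlier step, the result shows that the size of this change depends on the core that carries it: the same change on two cores in this assay, a 19-fold higher number (1.29 log units; beyond the scatter) from compound 1 to compound 3 and a 1.8-fold lower number (0.24 log units; within the scatter) from compound 2 to compound 4, 34-fold (1.53 log units) apart, beyond the scatter of two such steps

For the compounds shown here, with only two pairs, this does not show how the change would behave on any further core, nor why the two cores differ.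

The compounds shown leave open what a phenyl ring carrying an amine in place of the nitro group would do in this assay. They also leave open whether a longer chain would alter the effect of the change again.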